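Ring substituents on the ketone aryl group of compound 4

The compounds below may be only part of what the source reports. "The series", "measured", "known", "first", "only" and "open" are said of these compounds alone.

Measured compounds:
Compound 1, `COc1ccc(/C=C/c2cc(OC)cc(OC)c2/C=C/C(=O)c2ccc(Cl)c(Cl)c2)cc1`: 5.9 ug/mL
Compound 2, `COc1ccc(/C=C/c2cc(OC)cc(OC)c2/C=C/C(=O)c2ccc(C(F)(F)F)cc2)cc1`: 7.8 ug/mL
Compound 3, `COc1ccc(/C=C/c2cc(OC)cc(OC)c2/C=C/C(=O)c2ccc(N)cc2)cc1`: 3.8 ug/mL

In a functional assay on A549 cells (Homo sapiens) for antiproliferative activity, read by MTT assay, with a stated time of 48 h (a higher number here means a weaker inhibitor, a lower number a stronger inhibitor), compound 2 gives the highest of the three numbers. Its neighbour compound 1 stands close: a 1.3-fold higher number from compound 1 to compound 2 (0.12 log units; within the scatter). Compound 3 stands apart: a 2.1-fold lower number from compound 2 to compound 3 (0.31 log units; beyond the scatter). Compound 1 and compound 3 are separated by a 1.6-fold lower number from compound 1 to compound 3 (0.19 log units; within the scatter).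

The unmeasured compound 4, `COc1ccc(/C=C/c2cc(OC)cc(OC)c2/C=C/C(=O)c2ccc(C)c(C)c2)cc1`, is reached from compound 2 by one change: 3,4-dimethylphenyl in place of 4-(trifluoromethyl)phenyl on a carbonyl carbon. The step that bears most directly on it is the one between the two halogen-bearing aryl groups, a 1.3-fold higher number from compound 1 to compound 2 (0.12 log units; within the scatter), which stays within the scatter; the amino-bearing compound 3 is the only one beyond it. Among the measured compounds shown here, a dimethyl-bearing ring has no close precedent here, so the expected step is small. Compound 4 is therefore expected to sit near compound 2 and compound 1, with an estimated 1.2-fold lower number from compound 2 to compound 4 (0.08 log units; within the scatter). For compound 4 in this assay the estimated value is 6.5 ug/mL, with a range from 3.5 ug/mL to 12 ug/mL.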

Compound 4, half-maximal inhibitory concentration: 0.1 ug/mL
For compound 4 the middle estimate is 65-fold (1.81 log units) above the measured one, and the stated range ends above it.
By their numbers in this assay, from the lowest: compound 4; then compounds 3, 1 and 2 (each within the scatter of the next, the first and the last beyond it).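

In this assay the ketone aryl group proved a far more sensitive position than compound 1, compound 2 and compound 3 had shown, for 3,4-dimethylphenyl in place of 4-(trifluoromethyl)phenyl gives a 78-fold lower number from compound 2 to compound 4 (1.89 log units; beyond the scatter), and the aminated ring offers no match either, with a 38-fold lower number from compound 3 to compound 4 (1.58 log units; beyond the scatter). The ring pattern alone does not carry the gain: 3,4-dimethylphenyl and 3,4-dichlorophenyl share it, yet the exchange gives a 59-fold lower number from compound 1 to compound 4 (1.77 log units; beyond the scatter). Nothing measured here accounts for this gain.

The compounds shown leave open whether both methyl groups are needed, as a 4-methylphenyl group would test. They also leave open whether larger groups on the same ring, such as 3,4-diethylphenyl or 3,4-dimethoxyphenyl, would keep the gain.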